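The source may report more compounds than this note shows. Statements on the series, on what has been measured and on what is new or still open speak of the compounds shown alone.

In an ADME assay on HEK293 cells (Homo sapiens) for cytotoxicity, with a stated time of 72 h (a lower number here means that less compound is needed, a higher number that more compound is needed for the effect), compound 1 `CCOC(=O)/C(C)=C/c1cc(/C=C/[C@](C)(/C=C/c2ccc(OC)cc2)CCC=C(C)C)ccc1O` gives > 36600 nM, which is a limit of the assay and not a number. From the compounds shown here alone, compound 2 `COc1ccc(/C=C/[C@@](C)(/C=C/c2ccc(O)c(/C=C/C(=O)OCc3ccccc3)c2)CCC=C(C)C)cc1` gives > 36600 nM, which is also a limit, so its true position on the scale remains unknown. Compound 3 `COc1ccc(/C=C/[C@@](C)(/C=C/c2ccc(O)c(/C=C/C(C)=O)c2)CCC=C(C)C)cc1` changes one end of compound 2: methyl in place of benzyloxy on a carbonyl carbon, which turns benzyloxycarbonyl to acetyl (methyl in place of benzyloxy on a carbonyl carbon). Among the compounds with values here, the only measured step near this change is a step that the two limits leave unreadable from compound 1 to compound 2, and it offers no size to carry over. The remaining guide is the limit of > 36600 nM in this assay, at which 2 of the 2 values shown sit, so no large change is expected in this assay, and any shift would most likely be small and towards less compound needed. The estimated step is an at least 1.2-fold lower number from compound 2 to compound 3 (0.08 log units; that floor lies within the scatter). For compound 3 the expected value is 30000 nM, with an estimated range from 10000 nM to 50000 nM.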

Compound 3, half-maximal effective concentration: 14600 nM
Beside the measured number, compound 3's estimate is 2.1-fold (0.31 log units) above it; the range from low to high includes it.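

In this assay, methyl in place of benzyloxy on a carbonyl carbon gives an at least 2.5-fold lower number from compound 2 to compound 3 (0.39 log units; beyond the scatter), which shows that this end of the molecule can shift the read-out, something the earlier pair could not show, as the step between compound 1 and compound 2 cannot be read. Likewise, 2-acetylethenyl in place of 2-(ethoxycarbonyl)prop-1-en-1-yl on an aromatic carbon gives an at least 2.5-fold lower number from compound 1 to compound 3 (0.39 log units; beyond the scatter). Compound 3 is the only compound here with a real number rather than a limit: the limit of > 36600 nM in this assay, at which 2 of the 3 values shown sit.

From the compounds shown here alone, the full size of both steps stays open, and only their minimum is known. Also open, going by these compounds, is what an amine or a hydroxyl group on the same carbonyl carbon would do in place of methyl, and how a longer chain such as ethyl would compare.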